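Furan acid to cyclohexyl ester: notes on the series

A few compounds are considered here, and "the series" means these few. Any claim that something is new, unique, unknown or untested is made for them only; others in the source may bear on it.

In a functional assay on the whole organism (strain CD1) for inhibition, with Mus musculus as the target, with stated times of 15 min and 20 min, at a dose of 10 mg/kg by the subcutaneous route (a higher number here means more inhibition at the dose given (going by the name of the read-out), a lower number less inhibition), compound 1 `N#C/C(=C\c1c[nH]cn1)C(=O)OC1CCCCC1` gives 50%, compound 2 `N#C/C(=C\c1ccoc1)C(=O)O` gives 30.7% and compound 3 `NC/C(=C\c1ccoc1)C(=O)O` gives -1.5%. Among the measured compounds shown here, the one single-point step measured so far, a number 32.2 percentage points lower from compound 2 to compound 3 (beyond the scatter), concerns the cyano group, not the ester. Compound 2 stands second of the three numbers, beyond the scatter from both compound 1 above it and compound 3 below it. Compound 4 `N#C/C(=C\c1ccoc1)C(=O)OC1CCCCC1` differs from compound 2 by cyclohexyl in place of hydrogen on an oxygen next to a carbonyl group. For the measured compounds named here, no measured step covers this change; compound 1 and compound 2 differ in two places, so their values alone hint that an ester can run higher. A modest upward step is expected, a number 11.3 percentage points higher from compound 2 to compound 4 (beyond the scatter). For compound 4 the expected inhibition is 42%, within 18% to 66%.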

Compound 4, a percentage reported as inhibition, in the whole organism at one dose (the size of the read-out at that dose, not a potency): 91.2%
Estimate against measurement, compound 4: 49.2 percentage points below; the measured number lies above the stated range.
By their numbers in this assay, from the lowest: compound 3; then compound 2; then compound 1; then compound 4.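

In this assay the step of a number 60.5 percentage points higher from compound 2 to compound 4 (beyond the scatter) shows that cyclohexyl in place of hydrogen on an oxygen next to a carbonyl group brings a large gain on its own, which the two-place gap between compound 1 and compound 2 could not separate. The step of a number 41.2 percentage points higher from compound 1 to compound 4 (beyond the scatter) shows that, with cyclohexyl held, furan-3-yl in place of 1H-imidazol-4-yl also counts. Nothing on hand explains either step. Still open, as far as these compounds go, is whether methyl or a longer chain on that oxygen gives a similar step, and whether aminomethyl in place of cyano lowers the number as far with cyclohexyl present.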